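The compounds below may be only part of what the source reports. "The series", "measured", "known", "first", "only" and "open" are said of these compounds alone.

Compound 2 `CCC(CC)(c1ccc(OCC(O)C(C)(C)C)c(C)c1)c1ccc(C(=O)N[C@@H](C)CO)n1C` carries a 1-(hydroxymethyl)ethyl group on the amide-type nitrogen of the shared core. Going by the values given here, in an assay on HL-60 cells for agonist activity at vitamin D3 receptor (Homo sapiens), with a stated time of 96 h (on this read-out lower numbers stand for an effect already at smaller amounts and higher numbers for an effect only at larger amounts of compound), compound 2 gives 570 nM, the higher of the two numbers measured so far. Among the compounds with values here, its only measured neighbour is compound 1 `CCC(CC)(c1ccc(OCC(O)C(C)(C)C)c(C)c1)c1ccc(C(=O)NCCCO)n1C`, which bears a 3-hydroxypropyl group on the same nitrogen; in this assay compound 1 gives 150 nM. Within the data shown here, the one measured comparison is a 3.8-fold higher number from compound 1 to compound 2 (0.58 log units; beyond the scatter). Compound 3 `CCC(CC)(c1ccc(OCC(O)C(C)(C)C)c(C)c1)c1ccc(C(=O)N[C@H](CO)CCO)n1C` differs from compound 2 by hydroxymethyl in place of hydrogen on a saturated chain carbon, two bonds along the chain from an amide-type nitrogen. Among the measured compounds shown here, no measured step adds a hydroxymethyl group, so the single available step offers only indirect guidance: it shows that reshaping this hydroxylated side chain does shift the number, though not greatly. For compound 3 a step of about a 1.4-fold lower number from compound 2 to compound 3 (0.15 log units; within the scatter) is therefore expected, leaning toward the number of compound 1 but with wide uncertainty. The estimate for compound 3 is 400 nM, with a range from 130 nM to 1200 nM.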

Compound 3, half-maximal effective concentration: 200 nM
Estimate against measurement, compound 3: 2.0-fold (0.30 log units) above; the range from low to high includes it.
By their numbers in this assay, from the lowest: compounds 1 and 3 (each within the scatter of the next); then compound 2.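

In this assay, adding hydroxymethyl on a saturated chain carbon, two bonds along the chain from an amide-type nitrogen, gives a 2.9-fold lower number from compound 2 to compound 3 (0.45 log units; beyond the scatter) and shows that this position responds to an added hydroxylated group. The earlier pair showed only that exchanging one side chain for another shifts the number. Placing hydroxymethyl on the 3-hydroxypropyl chain, on the saturated chain carbon bound to an amide-type nitrogen and a saturated chain carbon, gives a 1.3-fold higher number from compound 1 to compound 3 (0.12 log units; within the scatter) and so leaves no readable difference, and no measurement here explains either result. On these data alone, whether an amine or a carboxylic acid in place of the hydroxymethyl would lower the number further remains open. So does the outcome for a longer chain at this position.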